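A Methoxycarbonyl Group on the Unsubstituted Aryl Ring

The compounds below may be only part of what the source reports. "The series", "measured", "known", "first", "only" and "open" are said of these compounds alone.

Compound 3 `O=C1C=CC(OCC(F)(F)F)N1c1ccccc1` gives only a limit of > 100000 nM in a functional assay on HeLa cells (Homo sapiens) for inhibition; on this read-out lower numbers stand for stronger inhibition and higher numbers for weaker inhibition. This places it weakest among the measured compounds, as compound 1 `O=C1C=CC(OCC(F)(F)F)N1c1ccc(C(F)(F)F)cc1` gives 36200 nM and compound 2 `CC(C)c1ccc(N2C(=O)C=CC2OCC(F)(F)F)cc1` gives 5800 nM in this assay. Compound 4 `COC(=O)c1ccc(N2C(=O)C=CC2OCC(F)(F)F)cc1` differs from compound 3 by methoxycarbonyl in place of hydrogen on an aromatic carbon. Among the compounds with values here, two measured steps bear on this change, both arriving at compound 3: an at least 2.7-fold higher number from compound 1 to compound 3 (0.44 log units; beyond the scatter) and an at least 17-fold higher number from compound 2 to compound 3 (1.23 log units; beyond the scatter). Both show that a group at this position lowers the number, so a downward step in this assay beyond the scatter is expected for compound 4, an at least 3.3-fold lower number from compound 3 to compound 4 (0.52 log units; beyond the scatter). Since compound 3 carries a limit (the limit of > 100000 nM in this assay, at which 1 of the 3 values shown sits), the true size of that step is uncertain. Compound 4 is estimated at 30000 nM, between 8000 nM and 100000 nM.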

Compound 4, half-maximal inhibitory concentration: 5700 nM
Beside the measured number, compound 4's estimate is 5.3-fold (0.72 log units) above it, outside the stated range (below it).
By their numbers in this assay, from the lowest: compounds 4 and 2 (each within the scatter of the next); then compound 1. At a limit, above all of these: compound 3.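

In this assay, methoxycarbonyl on the aromatic carbon para to a large group brings an at least 17-fold lower number from compound 3 to compound 4 (1.24 log units; beyond the scatter), showing that this position accepts a group with hydrogen-bond acceptors as well as the isopropyl of compound 2. The exchange for isopropyl gives a 1.0-fold lower number from compound 2 to compound 4 (0.01 log units; within the scatter), while the exchange for trifluoromethyl gives a 6.4-fold lower number from compound 1 to compound 4 (0.80 log units; beyond the scatter), so among these three groups only trifluoromethyl falls behind. Compound 3 stands at a limit, so the first step has no fixed size: the limit of > 100000 nM in this assay, at which 1 of the 4 values shown sits.

The compounds shown leave open whether a carboxylic acid or an amine at this position would match methoxycarbonyl. They also leave open whether methoxycarbonyl would give the same result elsewhere on the ring.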